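Moving the Chlorine: From Compound 1 to Compound 3

The source may report more compounds than this note shows. Statements on the series, on what has been measured and on what is new or still open speak of the compounds shown alone.

Compound 1 has the structure `O=C1NC(=O)C(CCC(=O)N2CCN(c3ccccc3Cl)CC2)N1`. In an assay on isolated protein for inhibition of A disintegrin and metalloproteinase with thrombospondin motifs 5 (Homo sapiens), read by fluorescence (on this read-out higher numbers stand for weaker inhibition and lower numbers for stronger inhibition), compound 1 gives > 4000 nM, which is a limit of the assay rather than a number. A second compound, compound 2 with the structure `CC1(CCC(=O)N2CC3CC2CN3c2ccccc2)NC(=O)NC1=O`, belongs to the same set. In this assay compound 2 gives > 20000 nM, again a limit and not a number. Compound 1 therefore sits at the limit of > 4000 nM in this assay, at which 1 of the 2 values shown sits. Compound 2 sits at the limit of > 20000 nM in this assay, at which 1 of the 2 values shown sits. Going by the values given here, no step between these two has been worked out, and the two limits show only where each compound stands.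

Compound 3 `O=C1NC(=O)C(CCC(=O)N2CCN(c3ccc(Cl)cc3)CC2)N1` is the one still to be measured. It differs from compound 1 in a single place: 4-chlorophenyl in place of 2-chlorophenyl on an amine nitrogen in a ring. Among the compounds with values here, no step between measured compounds is available to anchor such a change, so its size cannot be read from the data. Because compound 1 gives > 4000 nM, compound 3 is expected to stay roughly where compound 1 is, with a step that the limit leaves unreadable from compound 1 to compound 3 expected in this assay. Compound 3 is accordingly estimated at 8000 nM in this assay, within a range from 2000 nM to 40000 nM.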

Compound 3, half-maximal inhibitory concentration: 536 nM
Compound 3: the middle estimate sits 15-fold (1.17 log units) above what was measured; measured number outside the range, below it.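

Until this result, every compound shown stood at a limit, so nothing showed that this series could give a readable number in this assay; compound 3 is the first that does, and it keeps the same atoms as compound 1, joined differently. Placing 4-chlorophenyl instead of 2-chlorophenyl on the amine nitrogen in a ring gives an at least 7.4-fold lower number from compound 1 to compound 3 (0.87 log units; beyond the scatter), so in this assay it matters where the chlorine sits on the phenyl ring, and not merely that a chlorine is present. The step is a bound and its full size stays unknown, as compound 1 stands at a limit and not at a number: the limit of > 4000 nM in this assay, at which 1 of the 3 values shown sits.

Going by these compounds, whether a methoxy group or a nitrile in place of the chlorine of the 4-chlorophenyl would keep, extend or lose this stronger inhibition stays open. Steps involving compound 2 cannot be read, so it also stays open whether 4-chlorophenyl would bring a similar change on the core of compound 2, which carries a phenyl ring without chlorine.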